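The compounds below may be only part of what the source reports. "The series", "measured", "known", "first", "only" and "open" are said of these compounds alone.

Three related compounds have been tested so far in a functional assay on T98G cells (Homo sapiens) for cytotoxicity, read by MTT assay, with a stated time of 48 h; on this read-out higher numbers stand for weaker inhibition and lower numbers for stronger inhibition. Compound 1 `C/C(=N\NC(=S)Nc1ccccc1I)c1ccccn1` gives 8.09 nM, compound 2 `C/C(=N\NC(=S)Nc1ccc(Cl)cc1)c1ccccn1` gives 5.9 nM, and compound 3 `CC(=NNC(=S)Nc1ccccc1F)c1ccccn1` gives 3.1 nM. Compound 2 stands within the usual scatter of repeated measurements from both compound 1 and compound 3, so its number cannot be told apart from either of theirs.

Compound 4 `C/C(=N\NC(=S)Nc1ccc(I)cc1)c1ccccn1` has not yet been measured. It differs from compound 2 in a single place: iodo in place of chloro on an aromatic carbon. In words, this is iodo in place of chloro on an aromatic carbon, para to a large group. Within the data shown here, no two measured compounds differ in only one place, so the data offer no direct measure of what this swap does.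

The closest guide is compound 1, which also carries iodo. Its 8.09 nM lies within the scatter of the value for compound 2, which gives no sign of a large shift in either direction. The expected change is a 1.1-fold higher number from compound 2 to compound 4 (0.04 log units; within the scatter), a step that should stay within the scatter.

For compound 4 the estimated value is 6.5 nM, with an expected range of 2.5 nM to 16 nM.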

Compound 4, half-maximal inhibitory concentration: 64 nM
Beside the measured number, compound 4's estimate is 9.8-fold (0.99 log units) below it; the measured number lies above the stated range.
By their numbers in this assay, from the lowest: compounds 3, 2 and 1 (each within the scatter of the next, the first and the last beyond it); then compound 4.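

In this assay, exchanging chloro for iodo on an aromatic carbon, para to a large group, is far from a neutral swap of one halogen for another: it brings an 11-fold higher number from compound 2 to compound 4 (1.04 log units; beyond the scatter) and so a clear loss of inhibition. Compound 1 also carries iodo and gives 8.09 nM, so the presence of iodo on the shared core does not alone fix the number, and for compound 4 the group and its place have to be read together. Nothing measured here explains why this single-atom exchange has so large an effect.

The compounds shown leave open how bromo at this same place would behave, and so whether the large step appears only with iodo or already with a smaller change from chloro. They also leave open whether a methyl or a methoxy group on that carbon, or simply a hydrogen, would give a number close to that of compound 2 at 5.9 nM or one closer to that of compound 4 at 64 nM.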